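The source may report more compounds than this note shows. Statements on the series, on what has been measured and on what is new or still open speak of the compounds shown alone.

Compound 1 `COc1ccc(-c2coc3cc(OCCCSC(=S)N4CCOCC4)ccc3c2=O)cc1` was tested in a functional assay on ECa-109 cells for inhibition, with ECa-109 cell line (Homo sapiens) as the target, read by MTT assay, with a stated time of 48 h (a higher number here means a weaker inhibitor, a lower number a stronger inhibitor), where compound 1 gives 34000 nM. Among the three measured compounds it holds the second highest number: compound 2 `COc1ccc(-c2coc3cc(OCCCSC(=S)N4CCN(c5ccccn5)CC4)ccc3c2=O)cc1` gives 38300 nM, and compound 3 `COc1ccc(-c2coc3cc(OCCSC(=S)N4CCN(C(=O)OC(C)(C)C)CC4)ccc3c2=O)cc1` gives 4090 nM. The step of a 1.1-fold higher number from compound 1 to compound 2 (0.05 log units; within the scatter) shows that exchanging one amine part of the thiocarbonyl group for another left the number essentially unchanged. Compound 4 `COc1ccc(-c2coc3cc(OCCCBr)ccc3c2=O)cc1` departs from compound 1 by a different kind of change: one bromine atom in place of a group of 9 heavy atoms (5 carbon, 1 nitrogen, 1 oxygen, 2 sulfur; one six-membered non-aromatic ring with 2 hetero atoms), on a saturated chain carbon, three bonds along the chain from an oxygen on an aromatic ring. Within the data shown here, no measured step removes this group entirely, so the only guide is that the amine part of it seemed not to matter. The account therefore expects compound 4 to stay close to compound 1, with a step of a 1.2-fold higher number from compound 1 to compound 4 (0.07 log units; within the scatter) that is estimated to lie within the scatter, giving an expected value of 40000 nM, with a range from 14000 nM to 110000 nM.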

Compound 4, half-maximal inhibitory concentration: 39700 nM
Estimate against measurement, compound 4: 1.0-fold (0.00 log units) above, within the range that was stated.
By their numbers in this assay, from the lowest: compound 3; then compounds 1, 2 and 4 (each within the scatter of the next).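

In this assay, the step of a 1.2-fold higher number from compound 1 to compound 4 (0.07 log units; within the scatter) lies within the scatter, although a single bromine atom replaces the whole group with its six-membered non-aromatic ring. The earlier step exchanged only the amine part, whereas this one shows that the number also holds when the entire group leaves this saturated chain carbon. Nothing measured here explains this.

As far as these compounds go, whether a carboxylic acid or a primary amine on this carbon would leave the number unchanged stays open. From the compounds shown here alone, compound 3 differs from compound 1 in more than one place, so the source of its lower number also stays open.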